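Compound 4: 1-carboxyethyl on the amide-type nitrogen

The source may hold more compounds than are shown below. What is called first, only, known or untested is meant among the compounds shown, and "the series" means these compounds.

Three amides on a shared core have been read in a functional assay on BXPC-3 cells (Homo sapiens) for antiproliferative activity, read by MTT assay, with a stated time of 24 h; a lower number here means a stronger inhibitor, a higher number a weaker inhibitor: compound 1 (`CCn1c(C(=O)N[C@H](C)C(=O)OC)ccc1C(CC)(CC)c1ccc(OCS(=O)(=O)c2ccccc2)c(C)c1`), compound 2 (`CCn1c(C(=O)N[C@H](CO)C(C)C)ccc1C(CC)(CC)c1ccc(OCS(=O)(=O)c2ccccc2)c(C)c1`) and compound 3 (`CCn1c(C(=O)N[C@@H](CO)CCO)ccc1C(CC)(CC)c1ccc(OCS(=O)(=O)c2ccccc2)c(C)c1`). Compound 3 gives > 50000 nM, which is a limit of the assay and not a number. Compound 1 gives > 50000 nM, which is also a limit. Only compound 2 has a true number, 7720 nM.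

Compound 4 (`CCn1c(C(=O)N[C@H](C)C(=O)O)ccc1C(CC)(CC)c1ccc(OCS(=O)(=O)c2ccccc2)c(C)c1`) carries 1-carboxyethyl in place of 3-hydroxy-1-(hydroxymethyl)propyl on an amide-type nitrogen. Two readable steps bear on this change, an at least 6.4-fold lower number from compound 1 to compound 2 (0.81 log units; beyond the scatter) and an at least 6.4-fold higher number from compound 2 to compound 3 (0.81 log units; beyond the scatter). Both are at least modest and beyond the scatter, and both turn on the 1-(hydroxymethyl)-2-methylpropyl group of compound 2, which compound 4 lacks. The third step, a step that the two limits leave unreadable from compound 1 to compound 3, cannot be sized.

No step beyond the scatter is therefore expected in this assay, and the expected change is a number no higher from compound 3 to compound 4 (the limit leaves the size open). Compound 4 is estimated at 50000 nM, with an expected range of 20000 nM to 100000 nM.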

Compound 4, half-maximal inhibitory concentration: 20100 nM
For compound 4 the middle estimate is 2.5-fold (0.40 log units) above the measured one; low and high end bracket the measured number.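

In this assay, hydrogen in place of methyl on the oxygen next to the carbonyl group brings this side chain within the measurable range, giving an at least 2.4-fold lower number from compound 1 to compound 4 (0.39 log units; beyond the scatter), and 1-carboxyethyl in place of 3-hydroxy-1-(hydroxymethyl)propyl gives an at least 2.4-fold lower number from compound 3 to compound 4 (0.39 log units; beyond the scatter). The 1-(hydroxymethyl)-2-methylpropyl group keeps its lead, with a 2.6-fold higher number from compound 2 to compound 4 (0.42 log units; beyond the scatter), yet a true number on this amide-type nitrogen is now no longer confined to that one group. Two of these steps give only a minimum size because each starts from a limit of the assay and not from a number: the limit of > 50000 nM in this assay, at which 2 of the 4 values shown sit.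

The compounds shown leave open how an amine, a primary amide or a longer chain ending in a carboxylic acid would read on this nitrogen. They also leave open whether the mirror-image form of 1-carboxyethyl would read the same.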